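Naphthalene Replaces the Formylphenyl Group in Compound 4

The source may hold more compounds than are shown below. What is called first, only, known or untested is meant among the compounds shown, and "the series" means these compounds.

Three compounds share one core: compound 1 `c1ccc2c(-c3cn4ccnc4c(-c4ccc5ncn(C6CCCCC6)c5c4)n3)cccc2c1`, compound 2 `CCc1ccc(-c2cn3ccnc3c(-c3ccc4ncn(Cc5ccccc5)c4c3)n2)cc1` and compound 3 `O=Cc1ccc(-c2cn3ccnc3c(-c3ccc4ncn(Cc5ccccc5)c4c3)n2)cc1`. In a functional assay on NCI-H460 cells (Homo sapiens) for inhibition, read by sulforhodamine B assay, with a stated time of 48 h, tested at 10 uM (a lower number here means less inhibition, a higher number more inhibition at the concentration tested (going by the name of the read-out)), compound 1 gives 3.61%, compound 2 gives 42% and compound 3 gives 37.8%. Compound 3 thus stands second highest of the three, near compound 2 and well above compound 1. Among the compounds with values here, the one measured step, a number 4.2 percentage points lower from compound 2 to compound 3 (within the scatter), is within the scatter. Compound 4 `c1ccc(Cn2cnc3ccc(-c4nc(-c5cccc6ccccc56)cn5ccnc45)cc32)cc1` differs from compound 3 by naphthalen-1-yl in place of 4-formylphenyl on an aromatic carbon. Within the data shown here, no measured step covers this change; compound 1 also carries a naphthalen-1-yl group, yet differs elsewhere as well, so its low value can only hint. Compound 4 is therefore expected to fall, a number 22.8 percentage points lower from compound 3 to compound 4 (beyond the scatter), to an estimated 15% in this assay, within 0% to 40%.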

Compound 4, a percentage reported as inhibition, at one concentration (the size of the read-out at that concentration, not a potency): 3.8%
Compound 4: the middle estimate sits 11.2 percentage points above what was measured, and the stated range covers the measured number.
By their numbers in this assay, from the lowest: compounds 1 and 4 (each within the scatter of the next); then compounds 3 and 2 (each within the scatter of the next).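

In this assay, this aromatic carbon proves sensitive to the change of aryl group: naphthalen-1-yl gives far less inhibition than 4-formylphenyl (a number 34 percentage points lower from compound 3 to compound 4 (beyond the scatter)) or 4-ethylphenyl (a number 38.2 percentage points lower from compound 2 to compound 4 (beyond the scatter)). With naphthalen-1-yl in place, benzyl and cyclohexyl on the aromatic nitrogen are not told apart (a number 0.2 percentage points higher from compound 1 to compound 4 (within the scatter)). Nothing available explains the drop. From the compounds shown here alone, whether an aminophenyl or carboxyphenyl group on this carbon would retain inhibition remains open, as does whether benzyl and cyclohexyl would differ alongside 4-formylphenyl.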